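Swapping methyl for chloro on the outer phenyl ring

A few compounds are considered here, and "the series" means these few. Any claim that something is new, unique, unknown or untested is made for them only; others in the source may bear on it.

Compound 3 `Cc1ccccc1-n1cc(-c2ccc(NS(=O)(=O)c3c[nH]c(=O)[nH]c3=O)cc2)nn1` was tested in a functional assay on SGC-7901 cells (Homo sapiens) for antiproliferative activity, read by MTT assay, with a stated time of 24 h (a lower number here means a stronger inhibitor, a higher number a weaker inhibitor), where compound 3 gives 13600 nM. That is the highest of the three numbers seen so far. Compound 1 `O=c1[nH]cc(S(=O)(=O)Nc2ccccc2-c2cn(-c3ccccc3F)nn2)c(=O)[nH]1` is its nearest neighbour, with compound 1 giving 10800 nM, a gap that sits within the scatter. Compound 2 `O=c1[nH]cc(S(=O)(=O)Nc2cccc(-c3cn(-c4cccc(Cl)c4)nn3)c2)c(=O)[nH]1` lies furthest off, with compound 2 giving 3950 nM, a gap beyond the scatter. Compound 4 `O=c1[nH]cc(S(=O)(=O)Nc2ccc(-c3cn(-c4ccccc4Cl)nn3)cc2)c(=O)[nH]1` is not yet measured. Its structure differs from compound 3 by chloro in place of methyl on an aromatic carbon. Among the measured compounds shown here, no measured pair shows this exchange, so the expected step is small and may not exceed the scatter, if anything towards a slightly lower number. Compound 4 is expected at 9000 nM, within 4000 nM to 20000 nM, an estimated step of a 1.5-fold lower number from compound 3 to compound 4 (0.18 log units; within the scatter).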

Compound 4, half-maximal inhibitory concentration: 2680 nM
Compound 4: middle estimate off by 3.4-fold (0.53 log units), on the high side, and the stated range ends above it.
By their numbers in this assay, from the lowest: compounds 4 and 2 (each within the scatter of the next); then compounds 1 and 3 (each within the scatter of the next).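

Among the compounds shown here, on the outer phenyl ring, at the place ortho to a large group, methyl and chloro are not interchangeable: in this assay the exchange gives a 5.1-fold lower number from compound 3 to compound 4 (0.71 log units; beyond the scatter) and provides the first step here between measured compounds that differ in one place. Replacing one heavy atom with another, with no hydrogen-bond donor or acceptor added, is enough to move the number beyond the usual scatter. Nothing measured here explains the size of this step.

As far as these compounds go, whether a methoxy group or a nitrile at this same place would lower the number further remains open. So does whether the exchange of methyl for chloro would give a similar step elsewhere on the outer ring.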